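Cyclohexyl in place of propyl on the acylguanidine

This account rests on a few compounds, and the source may have more. Where it says the series, first, only, none or still open, it means among the compounds named here.

Compound 2 `CCCNC(=O)/N=C(\N)Nc1cccc(-c2csc(N)n2)c1` gives 5250 nM in an assay on membranes from Sf9 cells for displacement of a labelled ligand from histamine H2 receptor (Homo sapiens), read by scintillation counting, with a stated time of 60 min (a higher number here means a weaker inhibitor, a lower number a stronger inhibitor), the highest of the three numbers recorded. Compound 1 `CCCCCCNC(=O)/N=C(\N)Nc1cccc(-c2csc(N)n2)c1` gives 692 nM in this assay, and compound 3 `Cc1nc(N)sc1CCCN/C(N)=N/C(=O)N[C@@H](C)c1ccccc1`, built on a different core, gives 51.3 nM. The change to compound 4 `N/C(=N\C(=O)NC1CCCCC1)Nc1cccc(-c2csc(N)n2)c1` is cyclohexyl in place of propyl on an amide-type nitrogen. For the measured compounds named here, the one step that bears on it is a 7.6-fold higher number from compound 1 to compound 2 (0.88 log units; beyond the scatter), in which shortening the chain on the amide-type nitrogen weakened binding; compound 4 restores the carbon count of compound 1 in a ring. A step back toward compound 1 is therefore expected, though its size is uncertain, so compound 4 is estimated at 800 nM, between 250 nM and 2500 nM, an expected step of a 6.6-fold lower number from compound 2 to compound 4 (0.82 log units; beyond the scatter).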

Compound 4, inhibition constant: 4470 nM
Estimate against measurement, compound 4: 5.6-fold (0.75 log units) below; the measured number lies above the stated range.
By their numbers in this assay, from the lowest: compound 3; then compound 1; then compounds 4 and 2 (each within the scatter of the next).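

In this assay, cyclohexyl and propyl on the amide-type nitrogen cannot be told apart, with a 1.2-fold lower number from compound 2 to compound 4 (0.07 log units; within the scatter) at this position. The gain seen with hexyl does not carry over to the ring, with a 6.5-fold higher number from compound 1 to compound 4 (0.81 log units; beyond the scatter) on the same nitrogen, so chain and ring are not interchangeable here. Nothing available here accounts for this difference between the hexyl chain and the cyclohexyl ring.

On these data alone, whether a longer chain, a cyclohexylmethyl group or a benzyl group on this nitrogen would track hexyl or cyclohexyl remains open. Also open, as far as these compounds go, is whether the same difference between hexyl and cyclohexyl would appear on the core of compound 3.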